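Side-group swap from compound 3 to compound 4

This account rests on a few compounds, and the source may have more. Where it says the series, first, only, none or still open, it means among the compounds named here.

Measured in an ADME assay on microsomes from liver (Homo sapiens) for metabolic stability, with a stated time of 30 min, tested at 1 uM; a lower number here means that the compound disappears faster, a higher number that the compound lasts longer:
compound 1 `COc1ccc2[nH]c(C(=O)N3CC(=O)N(Cc4ccccc4)[C@@H](CN4CCC5(CC4)CC5)C3)cc2c1` gives 0.867 h
compound 2 `COc1ccc2[nH]c(C(=O)N3CC(=O)N(Cc4ccccc4)[C@@H](N4[C@H](C)CCC[C@@H]4C)C3)cc2c1` gives 0.112 h
compound 3 `COc1ccc2[nH]c(C(=O)N3CC(=O)N(Cc4ccccc4)[C@@H](N4CCc5ccccc54)C3)cc2c1` gives 0.25 h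

Compound 3 stands second highest of the three, with compound 2 lower and compound 1 higher. Compound 4 `COc1ccc2[nH]c(C(=O)N3CC(=O)N(Cc4ccccc4)[C@@H](CN4CCC(C(C)C)CC4)C3)cc2c1` carries (4-isopropylpiperidin-1-yl)methyl in place of 2,3-dihydro-1H-indol-1-yl on a saturated ring carbon, that is, (4-isopropylpiperidin-1-yl)methyl in place of 2,3-dihydro-1H-indol-1-yl on a saturated ring carbon. For the measured compounds named here, two measured steps bear on this and point opposite ways: a 3.5-fold lower number from compound 1 to compound 3 (0.54 log units; beyond the scatter), yet a 2.2-fold higher number from compound 2 to compound 3 (0.35 log units; beyond the scatter). By structure, compound 1 is the nearer match to the entering group, so a modest rise is expected in this assay, with compound 2 going against it. The estimated change is a 2.2-fold higher number from compound 3 to compound 4 (0.34 log units; beyond the scatter), with wide uncertainty. The expected value for compound 4 is 0.55 h with 0.2 h to 1.3 h as the estimated range.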

Compound 4, half-life: 0.317 h
The estimate for compound 4 lay 1.7-fold (0.24 log units) above the measured number; the range from low to high includes it.
By their numbers in this assay, from the lowest: compound 2; then compounds 3 and 4 (each within the scatter of the next); then compound 1.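

In this assay, (4-isopropylpiperidin-1-yl)methyl and 2,3-dihydro-1H-indol-1-yl on this saturated ring carbon cannot be told apart, with a 1.3-fold higher number from compound 3 to compound 4 (0.10 log units; within the scatter). The piperidinylmethyl link alone therefore does not reproduce compound 1, given a 2.7-fold lower number from compound 1 to compound 4 (0.44 log units; beyond the scatter), although the step from 2,6-dimethylpiperidin-1-yl remains beyond the scatter, with a 2.8-fold higher number from compound 2 to compound 4 (0.45 log units; beyond the scatter). No evidence at hand accounts for these steps.

Still open, from the compounds shown here alone, is how a hydroxyl in place of the isopropyl would read in this assay. Going by these compounds, a morpholine in place of the piperidine remains an equally open question.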